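The compounds below may be only part of what the source reports. "The series", "measured", "known", "first", "only" and "open" are said of these compounds alone.

Measured compounds, values in an in vitro assay on HEK293 cells for displacement of a labelled ligand from adenosine receptor A2b (Homo sapiens); on this read-out higher numbers stand for weaker inhibition and lower numbers for stronger inhibition:
- compound 1, `CCCn1c(=O)c2nc(-c3cnn(Cc4cc(C(F)(F)F)ccc4Cl)c3)[nH]c2n(CCC)c1=O`: compound 1 gives 22 nM
- compound 2, `CCCn1c(=O)c2nc(-c3cnn(Cc4ccccc4C(F)(F)F)c3)[nH]c2n(CCC)c1=O`: compound 2 gives 37 nM
- compound 3, `CCCn1c(=O)c2nc(-c3cnn(Cc4cccc(Cl)c4)c3)[nH]c2n(CCC)c1=O`: compound 3 gives 18 nM

Compound 3 has the lowest number of the three, but its separation from compound 1 is small: a 1.2-fold lower number from compound 1 to compound 3 (0.09 log units; within the scatter). Against compound 2 the gap is larger, a 2.1-fold lower number from compound 2 to compound 3 (0.31 log units; beyond the scatter), while a 1.7-fold higher number from compound 1 to compound 2 (0.23 log units; within the scatter) stays inside the scatter. The three benzyl variants therefore sit close together, with no clear order apart from the modest separation of compound 2.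

Compound 4, `CCCn1c(=O)c2nc(-c3cnn(Cc4cccc(F)c4F)c3)[nH]c2n(CCC)c1=O`, is not yet measured. It differs from compound 3 by 2,3-difluorophenyl in place of 3-chlorophenyl on a saturated chain carbon bound to an aromatic nitrogen. Going by the values given here, no measured step exchanges a chlorine-bearing ring for a fluorine-bearing one, so the bearing steps are only the three benzyl swaps above, all of which are small. On that basis no step beyond the scatter is expected in this assay for compound 4; the expected step from compound 3 is a 1.4-fold higher number from compound 3 to compound 4 (0.14 log units; within the scatter). Compound 4 is estimated at 25 nM, with the range 10 nM to 60 nM.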

Compound 4, inhibition constant: 240 nM
For compound 4 the middle estimate is 9.6-fold (0.98 log units) below the measured one, and the stated range ends below it.
By their numbers in this assay, from the lowest: compounds 3, 1 and 2 (each within the scatter of the next, the first and the last beyond it); then compound 4.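

In this assay, going by these compounds alone, the group on a saturated chain carbon bound to an aromatic nitrogen is not as tolerant as the earlier compounds suggested: a 13-fold higher number from compound 3 to compound 4 (1.12 log units; beyond the scatter) and an 11-fold higher number from compound 1 to compound 4 (1.04 log units; beyond the scatter) are large steps, and a 6.5-fold higher number from compound 2 to compound 4 (0.81 log units; beyond the scatter) is a modest one. All three steps run towards weaker inhibition, so the ring carrying only fluorine stands apart from the three rings carrying chlorine, trifluoromethyl or both, whose mutual steps stayed small. Nothing measured on this series accounts for that separation.

From the compounds shown here alone, whether the loss needs both fluorines remains open, and a phenyl ring with a single fluorine would address that. Also open, going by these compounds, is how this place responds to a different kind of ring substituent, such as an amine or a carboxylic acid.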